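Compound 4: a chloro-methoxyphenyl replaces the dimethylpyridinyl

A few compounds are considered here, and "the series" means these few. Any claim that something is new, unique, unknown or untested is made for them only; others in the source may bear on it.

Of the compounds shown here, three built on one shared core have been measured in a functional assay on BJAB cells (Homo sapiens) for antiproliferative activity, with a stated time of 4 days; on this read-out higher numbers stand for an effect only at larger amounts of compound and lower numbers for an effect already at smaller amounts. Compound 1 `COc1cc(-c2c(C)nn(-c3nc(-c4ccc(Cl)c(Cl)c4)c(SC(C)C)s3)c2C(=O)O)cc(C(F)(F)F)c1` gives 1380 nM, compound 2 `Cc1cc(Cl)cc(-c2c(C)nn(-c3nc(-c4ccc(Cl)c(Cl)c4)c(SC(C)C)s3)c2C(=O)O)c1` gives 663 nM, and compound 3 `Cc1cc(-c2c(C)nn(-c3nc(-c4ccc(Cl)c(Cl)c4)c(SC(C)C)s3)c2C(=O)O)cc(C)n1` gives 580 nM, the lowest number of the three, although compound 2 lies within the scatter of it and only compound 1 stands clearly apart. Compound 4 `COc1cc(Cl)cc(-c2c(C)nn(-c3nc(-c4ccc(Cl)c(Cl)c4)c(SC(C)C)s3)c2C(=O)O)c1` differs from compound 3 in one place: 3-chloro-5-methoxyphenyl in place of 2,6-dimethylpyridin-4-yl on an aromatic carbon. The entering group carries the chloro of compound 2 together with the methoxy of compound 1; the steps of a 2.1-fold lower number from compound 1 to compound 2 (0.32 log units; beyond the scatter) and a 2.4-fold lower number from compound 1 to compound 3 (0.38 log units; beyond the scatter) were modest, whereas a 1.1-fold lower number from compound 2 to compound 3 (0.06 log units; within the scatter). A modest rise is therefore expected for compound 4, a 1.6-fold higher number from compound 3 to compound 4 (0.19 log units; within the scatter). Compound 4 is estimated at 900 nM, within a range from 450 nM to 1800 nM.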

Compound 4, half-maximal effective concentration: 760 nM
The estimate for compound 4 lay 1.2-fold (0.07 log units) above the measured number; low and high end bracket the measured number.
By their numbers in this assay, from the lowest: compounds 3, 2, 4 and 1 (each within the scatter of the next, the first and the last beyond it).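

In this assay, this position takes 3-chloro-5-methoxyphenyl, a ring of carbon only, about as well as 2,6-dimethylpyridin-4-yl, which has a ring nitrogen (a 1.3-fold higher number from compound 3 to compound 4 (0.12 log units; within the scatter)). Two single swaps on the phenyl ring also stay within the scatter: methoxy in place of methyl (a 1.1-fold higher number from compound 2 to compound 4 (0.06 log units; within the scatter)) and chloro in place of trifluoromethyl (a 1.8-fold lower number from compound 1 to compound 4 (0.26 log units; within the scatter)). No evidence is available to explain these steps. On these data alone, it remains open whether an amine or a hydroxy group on this ring would move the number beyond the scatter.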